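Chloro addition on the aniline ring: expected effect on cytotoxicity

The compounds below may be only part of what the source reports. "The series", "measured", "known", "first", "only" and "open" are said of these compounds alone.

Compound 1 `O=C(Nc1ccc(OC(F)(F)F)cc1)c1cc(F)ccc1O` is the parent of this set; in a functional assay on NALM-6 cells (Homo sapiens) for cytotoxicity, read by luminescence and CellTiter-Glo, with a stated time of 3 days (a lower number here means a stronger inhibitor, a higher number a weaker inhibitor), compound 1 gives 1210 nM. Compound 2 `O=C(Nc1ccc(OC(F)(F)F)c(Cl)c1)c1cc(F)ccc1O` carries chloro in place of hydrogen on an aromatic carbon and in this assay compound 2 gives 1000 nM, the step being a 1.2-fold lower number from compound 1 to compound 2 (0.08 log units; within the scatter). Compound 3 `O=C(Nc1ccc([N+](=O)[O-])cc1)c1cc(F)ccc1O` differs from compound 1 by nitro in place of trifluoromethoxy on an aromatic carbon; in this assay compound 3 gives 2080 nM, a step of a 1.7-fold higher number from compound 1 to compound 3 (0.24 log units; within the scatter). Compound 4 `O=C(Nc1ccc([N+](=O)[O-])cc1Cl)c1cc(F)ccc1O`, not yet measured, differs from compound 3 by chloro in place of hydrogen on an aromatic carbon. This is the same kind of change as that from compound 1 to compound 2, though the place differs: in compound 2 the chloro is ortho to a trifluoromethoxy group and meta to a large group, whereas in compound 4 it is ortho to a large group and meta to a nitro group. Resting on the single precedent a 1.2-fold lower number from compound 1 to compound 2 (0.08 log units; within the scatter), the expected step in this assay is a 1.2-fold lower number from compound 3 to compound 4 (0.09 log units; within the scatter). In this assay compound 4 is therefore estimated at 1700 nM, with 900 nM and 3300 nM as the expected lower and upper ends.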

Compound 4, half-maximal inhibitory concentration: 910 nM
Estimate against measurement, compound 4: 1.9-fold (0.27 log units) above; the range from low to high includes it.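

In this assay, chloro in place of hydrogen on an aromatic carbon gives a 2.3-fold lower number from compound 3 to compound 4 (0.36 log units; beyond the scatter), and the two steps do not differ beyond the scatter: the same change on two cores in this assay, a 1.2-fold lower number (0.08 log units; within the scatter) from compound 1 to compound 2 and a 2.3-fold lower number (0.36 log units; beyond the scatter) from compound 3 to compound 4, 1.9-fold (0.28 log units) apart, within the scatter of two such steps. The change can therefore be carried from the core of compound 1 to the core of compound 3 without a detectable difference in the size of the step. Going by these compounds alone, this does not establish a general rule, since it rests on only two steps, the chloro stands in a different place in each, and only the step to compound 4 lies beyond the scatter.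

The compounds shown leave open whether bromo, methyl or an amine on the same aromatic carbon would give a similar step. They also leave open whether chloro ortho to the large group would give the same step on the core of compound 1.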